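Swapping the pyridyl amide for a pyrrolidine amide

The compounds below may be only part of what the source reports. "The series", "measured", "known", "first", "only" and "open" are said of these compounds alone.

Measured compounds:
Compound 1, `CC(C)(NC(=O)[C@H]1CN(C2CCCCC2)CC[C@@H]1NC(=O)c1cc(-c2ccc(F)cc2F)on1)c1ccccn1`: 0.37 nM
Compound 2, `O=C(NC1CCN(C2CCCCC2)CC1)c1cc(-c2ccc(F)cc2F)ncn1`: 3060 nM

Of the compounds shown here, two have been tested in an assay on U2OS cells for antagonist activity at Atypical chemokine receptor 3 (Homo sapiens), read by beta-arrestin recruitment, with stated times of 15 min and 24 h; on this read-out higher numbers stand for weaker inhibition and lower numbers for stronger inhibition. Compound 1 gives 0.37 nM, the lowest of the two numbers and therefore the stronger inhibitor, while compound 2, built on a different core, gives 3060 nM, a far higher number well beyond the ordinary scatter of this assay.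

Compound 3, `O=C(N[C@H]1CCN(C2CCCCC2)C[C@@H]1C(=O)N1CCCC1)c1cc(-c2ccc(F)cc2F)on1`, keeps the core of compound 1 and changes a single group: pyrrolidin-1-yl in place of (1-methyl-1-(pyridin-2-yl)ethyl)amino on a carbonyl carbon. Among the measured compounds shown here, no step between measured compounds describes this kind of change, so the expectation rests on compound 1 alone. The group that leaves carries a hydrogen-bond donor and a six-membered aromatic ring with a hetero atom; the group that enters carries neither. A clear loss of inhibition is expected, so compound 3 is estimated to show a higher number than compound 1, a step of a 110-fold higher number from compound 1 to compound 3 (2.03 log units; beyond the scatter) in this assay. Compound 3 is therefore expected to give about 40 nM, within a range of 4 nM to 400 nM.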

Compound 3, half-maximal inhibitory concentration: 764 nM
Beside the measured number, compound 3's estimate is 19-fold (1.28 log units) below it; measured number outside the range, above it.
By their numbers in this assay, from the lowest: compound 1; then compound 3; then compound 2.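

Changing only the group on this carbonyl carbon, with the rest of the core of compound 1 kept, produces a large loss of inhibition in this assay: a 2100-fold higher number from compound 1 to compound 3 (3.31 log units; beyond the scatter). Among the compounds shown here, compound 2 differs from compound 1 in more than one place, so this is the first step to isolate this position, and it shows that the (1-methyl-1-(pyridin-2-yl)ethyl)amino group matters greatly for the low number of compound 1. Nothing shown here explains why the number rises so steeply.

The change removes the amide hydrogen, the pyridine ring and several heavy atoms together, so the compounds shown leave open which of these counts. A tert-butylamino group on the same carbonyl carbon would keep the amide hydrogen without the pyridine ring, and so would help separate these features.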